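Extending the Sulfonyl Aryl Ring with a Methylsulfonylphenyl Group

This account rests on a few compounds, and the source may have more. Where it says the series, first, only, none or still open, it means among the compounds named here.

Of the compounds shown here, two sharing one core have been measured in a functional assay on PC-3 cells (Homo sapiens) for inhibition; on this read-out higher numbers stand for weaker inhibition and lower numbers for stronger inhibition. Compound 1 `COc1cc2nc(N3CCN(S(=O)(=O)c4ccccc4[N+](=O)[O-])CC3)nc(N)c2cc1OC` carries a 2-nitrophenyl on its sulfonyl sulfur, and in this assay compound 1 gives 35000 nM. Compound 2 `COc1cc2nc(N3CCN(S(=O)(=O)c4ccc(C(F)(F)F)cc4)CC3)nc(N)c2cc1OC` carries a 4-(trifluoromethyl)phenyl there instead, and in this assay compound 2 gives 27000 nM. Going by the values given here, the only step between them, a 1.3-fold lower number from compound 1 to compound 2 (0.11 log units; within the scatter), shows that swapping the substituent on that aryl ring left the read-out essentially unchanged; the two numbers cannot be told apart.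

Compound 3 `COc1cc2nc(N3CCN(S(=O)(=O)c4ccc(-c5ccc(S(C)(=O)=O)cc5)cc4)CC3)nc(N)c2cc1OC` changes this same aryl ring once more: 4-(methylsulfonyl)phenyl in place of trifluoromethyl on an aromatic carbon. Among the compounds with values here, the one measured step bears on it only loosely, since it too altered the group on the sulfonyl aryl ring and was within the scatter. Within the data shown here, no measured pair tests a change of this size at this place, so the expectation is that compound 3 stays in the same region, with a step of a 1.1-fold lower number from compound 2 to compound 3 (0.03 log units; within the scatter) expected and no clear direction. Compound 3 is therefore estimated at 25000 nM, in the range 7000 nM to 90000 nM.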

Compound 3, half-maximal inhibitory concentration: 7200 nM
For compound 3 the middle estimate is 3.5-fold (0.54 log units) above the measured one, within the range that was stated.
By their numbers in this assay, from the lowest: compound 3; then compounds 2 and 1 (each within the scatter of the next).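

Putting 4-(methylsulfonyl)phenyl in place of trifluoromethyl gives a 3.8-fold lower number from compound 2 to compound 3 (0.57 log units; beyond the scatter) in this assay, so this position of the sulfonyl aryl ring can shift the read-out, even though the shift is modest. The earlier exchange of groups on this ring, a 1.3-fold lower number from compound 1 to compound 2 (0.11 log units; within the scatter), could not show this, since its two numbers cannot be told apart. The new step also shows that a much larger group can sit here without the number rising: 10 heavy atoms and a second six-membered aromatic ring replace 4 heavy atoms and no ring, and the number falls instead. Nothing measured here accounts for the lower number in compound 3.

The compounds shown leave open which part of the new group matters, the added aromatic ring or the methylsulfonyl at its far end. A plain phenyl at this place, or a phenyl carrying an amine or a carboxylic acid where the methylsulfonyl stands, would help to separate these two parts.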